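Working notes on three weak entries and a pending analogue

The source may hold more compounds than are shown below. What is called first, only, known or untested is meant among the compounds shown, and "the series" means these compounds.

Measured compounds in a functional assay on L02 cells (Homo sapiens) for inhibition, read by Griess assay, with stated times of 1 h and 24 h; on this read-out lower numbers stand for stronger inhibition and higher numbers for weaker inhibition:
- Compound 1, `C(=C/c1nc(Nc2ccccc2)c2sccc2n1)\c1ccccc1`: compound 1 gives > 1000000 nM; this is a limit of the assay, not a number.
- Compound 2, `CNc1nc(/C=C/c2ccco2)nc2ccsc12`: compound 2 gives 811000 nM.
- Compound 3, `COc1cc(/C=C/c2nc(N3CCN(C)CC3)c3sccc3n2)cc(OC)c1OC`: compound 3 gives > 1000000 nM; this too is a limit of the assay, not a number.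

Where compound 3 stands: only a limit is known for it in this assay, and the limit of > 1000000 nM in this assay, at which 2 of the 3 values shown sit, shows that two of the three values sit at that same limit, so compound 3 cannot be placed in order against compound 1 or compound 2 on the numbers shown.

The next compound, compound 4, `COc1cc(/C=C/c2nc(OCc3ccccc3)c3sccc3n2)cc(OC)c1OC`, differs from compound 3 in one place: benzyloxy in place of 4-methylpiperazin-1-yl on an aromatic carbon.

For the measured compounds named here, no measured pair differing in one place is available to size such a change. With both neighbours of this type at the limit and compound 2 close to it, no step beyond the usual scatter is expected in this assay, in either direction. Compound 4 is therefore expected to give about 1000000 nM, with a likely range from 400000 nM to 3000000 nM. The expected step is a number no higher from compound 3 to compound 4 (the limit leaves the size open), which most likely means another limit rather than a measured number.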

Compound 4, half-maximal inhibitory concentration: > 1000000 nM
Compound 4: only a limit was reported (the forecaster's own chance of this, stated with the estimate: 70%); the middle value sits exactly at the limit.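

In this assay compound 4 gives > 1000000 nM, which is a limit of the assay and not a number. Compound 3 also stands at a limit, so no step can be read between compound 3 and compound 4: the limit of > 1000000 nM in this assay, at which 3 of the 4 values shown sit.

The compounds shown leave open how benzyloxy and 4-methylpiperazin-1-yl compare in this assay on any compound that gives a measured number.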